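From 2,4-dimethylphenyl to 3,4-dimethylphenyl on a shared core

This account rests on a few compounds, and the source may have more. Where it says the series, first, only, none or still open, it means among the compounds named here.

Going by the values given here, in a functional assay on KB cells (Homo sapiens) for antiproliferative activity, read by sulforhodamine B assay, with a stated time of 3 days (a lower number here means that less compound is needed, a higher number that more compound is needed for the effect), compound 1 `CCC1=C(O)c2c(oc(-c3cccc(OC)c3)cc2=O)C(CC)(CC)C1=O` gives 13.3 uM, while compound 2 `CCC1=C(O)c2c(oc(-c3ccc(C)cc3C)cc2=O)C(CC)(CC)C1=O` gives 41.2 uM, the higher of the two numbers so far. Compound 3 `CCC1=C(O)c2c(oc(-c3ccc(C)c(C)c3)cc2=O)C(CC)(CC)C1=O` keeps the shared core and differs from compound 2 in one group, with 3,4-dimethylphenyl in place of 2,4-dimethylphenyl on an aromatic carbon next to the ring oxygen: 3,4-dimethylphenyl in place of 2,4-dimethylphenyl on an aromatic carbon. Among the compounds with values here, only one measured step bears on this change: a 3.1-fold higher number from compound 1 to compound 2 (0.49 log units; beyond the scatter). That modest step came with 2,4-dimethylphenyl replacing 3-methoxyphenyl, so it says little about a dimethylphenyl isomer, and no direct comparison exists. A modest move towards the value of compound 1 therefore seems likely, though it remains uncertain. The expected change in this assay is a 2.1-fold lower number from compound 2 to compound 3 (0.31 log units; beyond the scatter). For compound 3 the estimated value is 20 uM, with an expected range of 8 uM to 50 uM.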

Compound 3, concentration for half-maximal effect: 35.5 uM
For compound 3 the middle estimate is 1.8-fold (0.25 log units) below the measured one; measured number inside the range.
By their numbers in this assay, from the lowest: compound 1; then compounds 3 and 2 (each within the scatter of the next).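

In this assay, 3,4-dimethylphenyl in place of 2,4-dimethylphenyl on the aromatic carbon next to the ring oxygen gives a 1.2-fold lower number from compound 2 to compound 3 (0.06 log units; within the scatter), so this assay does not separate the two dimethylphenyl isomers. The 3-methoxyphenyl group stays apart from both: a 2.7-fold higher number from compound 1 to compound 3 (0.43 log units; beyond the scatter) stands alongside the earlier 3.1-fold higher number from compound 1 to compound 2 (0.49 log units; beyond the scatter), so the gap does not hang on which of these two isomers occupies this position. Nothing available here accounts for these results.

Going by these compounds, it remains open whether a phenyl ring carrying a hydroxyl group or a chlorine atom, or a pyridine ring at this position, would fall nearer to compound 1 or to the two dimethylphenyl compounds. Also open, on these data alone, is how the ethyl groups on the shared core bear on these numbers.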